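This account rests on a few compounds, and the source may have more. Where it says the series, first, only, none or still open, it means among the compounds named here.

Compound 3 `CCN1CCN(CCCSc2nnc(-c3ccccc3Cl)[nH]2)CC1` carries a 2-chlorophenyl group on the shared core and an ethyl group on a ring nitrogen. In a functional assay on HL-60 cells (Homo sapiens) for cytotoxicity, read by MTT assay, with a stated time of 24 h (a higher number here means a weaker inhibitor, a lower number a stronger inhibitor), compound 3 gives only a limit, > 300000 nM. Compound 1 `CCN1CCN(CCCSc2nnc(-c3ccc(C)cc3)[nH]2)CC1` bears 4-methylphenyl where compound 3 bears 2-chlorophenyl. In this assay compound 1 also gives only a limit, > 300000 nM. The step that the two limits leave unreadable from compound 1 to compound 3 therefore cannot be read, as both values sit at the limit of > 300000 nM in this assay, at which 2 of the 3 values shown sit. Among the measured compounds shown here, compound 2 `Cc1cccc(-c2nnc(SCCCN3CCN(c4ccccn4)CC3)[nH]2)c1`, which has a pyridin-2-yl group on the ring nitrogen and a 3-methylphenyl group on the core, gives 29400 nM in this assay; compound 2 differs from compound 1 in two places, so the two values show only that a measurable number appears when the pyridin-2-yl group is present. Compound 4 `Clc1ccccc1-c1nnc(SCCCN2CCN(c3ccccn3)CC2)[nH]1` is compound 3 with the change (pyridin-2-yl in place of ethyl on an amine nitrogen in a ring). For the measured compounds named here, no measured step covers exactly this change. As compound 2 with its pyridin-2-yl group gives 29400 nM, compound 4 is expected to give 60000 nM, with a range from 20000 nM to 300000 nM. This means an expected step of an at least 5.0-fold lower number from compound 3 to compound 4 (0.69 log units; beyond the scatter).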

Compound 4, half-maximal inhibitory concentration: > 300000 nM
Compound 4 was reported as a limit (the forecaster's own chance of this, stated with the estimate: 35%); at least 5.0-fold (0.69 log units) between middle value and limit.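

The change from ethyl to pyridin-2-yl on the ring nitrogen cannot be read, as compound 3 and compound 4 sit at the same limit: the limit of > 300000 nM in this assay, at which 3 of the 4 values shown sit. With pyridin-2-yl held in place, the group on the core does matter: in this assay, 2-chlorophenyl in place of 3-methylphenyl gives an at least 10-fold higher number from compound 2 to compound 4 (1.00 log units; beyond the scatter). So pyridin-2-yl alone does not bring a measurable number, and among the compounds shown only compound 2, which pairs it with 3-methylphenyl, gives one.

Going by these compounds, it remains open whether the methyl group, the chlorine atom or the position of either accounts for this step, and 3-chlorophenyl or 2-methylphenyl on the core would help to separate these. A 3-methylphenyl compound with ethyl on the ring nitrogen could show whether the ethyl to pyridin-2-yl change has a readable size at all.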